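The source may report more compounds than this note shows. Statements on the series, on what has been measured and on what is new or still open speak of the compounds shown alone.

Measured compounds in this set:

Compound 1, `Nc1ccc(/C=C2\SC(=O)N(Cc3ccc(C(F)(F)F)cc3)C2=O)cc1`, with 6000 nM
Compound 2, `C=C(Br)C(=O)Nc1ccc(/C=C2\SC(=O)N(Cc3ccc(C(F)(F)F)cc3)C2=O)cc1`, with 12000 nM
Compound 3, `C=C(Br)C(=O)Nc1cccc(/C=C2\SC(=O)N(Cc3ccc(C)cc3)C2=O)c1`, with 600 nM

All three were tested in a functional assay on L1210 cells (Mus musculus) for cytotoxicity, read by cell counting, with a stated time of 2 days; on this read-out higher numbers stand for weaker inhibition and lower numbers for stronger inhibition. For the measured compounds named here, the one change that can be followed between measured compounds is hydrogen in place of (1-bromoethenyl)carbonyl on a nitrogen on an aromatic ring, which gave a 2.0-fold lower number from compound 2 to compound 1 (0.30 log units; within the scatter). Compound 3 carries the lowest number of the three; the difference between its core and the core of compound 2 is not broken down here, so the two values alone show that compound 3 sits well below compound 2 in this assay.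

Compound 4, `Cc1ccc(CN2C(=O)S/C(=C\c3cccc(N)c3)C2=O)cc1`, has not yet been measured. Relative to compound 3 it shows (hydrogen in place of (1-bromoethenyl)carbonyl on a nitrogen on an aromatic ring), the same change that was made from compound 2 to compound 1, at a place described in the same words. Because the earlier step, a 2.0-fold lower number from compound 2 to compound 1 (0.30 log units; within the scatter), stayed within the scatter, compound 4 is expected to land near compound 3, with a small downward lean; the estimated step is a 1.5-fold lower number from compound 3 to compound 4 (0.18 log units; within the scatter). Compound 4 is therefore expected to give about 400 nM in this assay, most likely between 150 nM and 1200 nM.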

Compound 4, half-maximal inhibitory concentration: 176000 nM
Beside the measured number, compound 4's estimate is 440-fold (2.64 log units) below it; the whole stated range lies below it.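

In this assay, hydrogen in place of (1-bromoethenyl)carbonyl on a nitrogen on an aromatic ring gave a 290-fold higher number from compound 3 to compound 4 (2.47 log units; beyond the scatter). For the compounds shown here, the size of this change therefore did not carry from one core to the other: the same change on two cores in this assay, a 2.0-fold lower number (0.30 log units; within the scatter) from compound 2 to compound 1 and a 290-fold higher number (2.47 log units; beyond the scatter) from compound 3 to compound 4, 590-fold (2.77 log units) apart, beyond the scatter of two such steps Across these four compounds, the result of the change depends on the core that carries it, but with only one pair on each core, the data do not show which difference between the cores goes with the gap, nor why the change counts for so much on one core and stays within the scatter on the other.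

As far as these compounds go, it remains open whether an acetyl group or a (1-chloroethenyl)carbonyl on that nitrogen would give a number closer to that of compound 3 or that of compound 4. Also open, from the compounds shown here alone, is how the same change would behave on any core other than these two.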